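The source may report more compounds than this note shows. Statements on the series, on what has been measured and on what is new or still open speak of the compounds shown alone.

Compound 3 `CNC(=O)[C@@]12C[C@@H]1[C@@H](n1cnc3c(NC)nc(C#Cc4cccnn4)nc31)[C@H](O)[C@@H]2O` carries a pyridazin-3-yl group on the triple bond of the shared core. In an assay on CHO cells for displacement of a labelled ligand from adenosine receptor A3 (Homo sapiens), read by scintillation counting, with a stated time of 60 min (a lower number here means a stronger inhibitor, a higher number a weaker inhibitor), compound 3 gives 3.53 nM. Compound 1 `CNC(=O)[C@@]12C[C@@H]1[C@@H](n1cnc3c(NC)nc(C#Cc4ccc(CO)cc4)nc31)[C@H](O)[C@@H]2O` gives 2.16 nM and compound 2 `CNC(=O)[C@@]12C[C@@H]1[C@@H](n1cnc3c(NC)nc(C#Cc4ncccn4)nc31)[C@H](O)[C@@H]2O` gives 1.97 nM; the steps of a 1.6-fold higher number from compound 1 to compound 3 (0.21 log units; within the scatter) and a 1.8-fold higher number from compound 2 to compound 3 (0.25 log units; within the scatter) both lie within the scatter, so these three compounds cannot be told apart on their numbers. Compound 4 `CNC(=O)[C@@]12C[C@@H]1[C@@H](n1cnc3c(NC)nc(C#CC4CC4)nc31)[C@H](O)[C@@H]2O` differs from compound 3 by cyclopropyl in place of pyridazin-3-yl on a triple-bonded carbon. For the measured compounds named here, the steps that bear on this exchange are the earlier swaps at the same position, a 1.1-fold lower number from compound 1 to compound 2 (0.04 log units; within the scatter) and a 1.8-fold higher number from compound 2 to compound 3 (0.25 log units; within the scatter), neither of which moved the number beyond the scatter. The expected step is therefore a 1.1-fold higher number from compound 3 to compound 4 (0.05 log units; within the scatter), small in either direction. Compound 4 is estimated to give 4 nM, with a range from 1.2 nM to 15 nM.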

Compound 4, inhibition constant: 1.15 nM
The estimate for compound 4 lay 3.5-fold (0.54 log units) above the measured number, and the stated range ends above it.
By their numbers in this assay, from the lowest: compounds 4, 2, 1 and 3 (each within the scatter of the next, the first and the last beyond it).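

In this assay, a small carbon-only ring on the triple-bonded carbon does as well as the aromatic groups. Cyclopropyl gives the first step at this position beyond the scatter (a 3.1-fold lower number from compound 3 to compound 4 (0.49 log units; beyond the scatter)), while the other two steps stay within it (a 1.7-fold lower number from compound 2 to compound 4 (0.23 log units; within the scatter)) (a 1.9-fold lower number from compound 1 to compound 4 (0.27 log units; within the scatter)). An aromatic ring is therefore not required here for a low number, though no evidence is available on the cause of this step. Still open, going by these compounds, is whether cyclobutyl, an open propyl chain or an amine at this position would keep the number this low.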